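A few compounds are considered here, and "the series" means these few. Any claim that something is new, unique, unknown or untested is made for them only; others in the source may bear on it.

In an assay on isolated protein for inhibition of Maltase-glucoamylase (Homo sapiens), with a stated time of 15 min (a higher number here means a weaker inhibitor, a lower number a stronger inhibitor), the measured compounds are: compound 1 `COc1ccc(O)c(/C=N/NC(=O)c2ccc(-c3nc4ccccc4s3)cc2)c1` gives 6500 nM; compound 2 `O=C(N/N=C/c1cccs1)c1ccc(-c2nc3ccccc3s2)cc1` gives 8480 nM; compound 3 `O=C(N/N=C/c1ccccc1O)c1ccc(-c2nc3ccccc3s2)cc1` gives 5550 nM.

Compound 3 stands apart from compound 1 by a 1.2-fold lower number from compound 1 to compound 3 (0.07 log units; within the scatter) and from compound 2 by a 1.5-fold lower number from compound 2 to compound 3 (0.18 log units; within the scatter), both within the scatter, so nothing separates the three numbers. Compound 4 `O=C(N/N=C/c1ccc([N+](=O)[O-])cc1)c1ccc(-c2nc3ccccc3s2)cc1` carries 4-nitrophenyl in place of 2-hydroxyphenyl on a carbon with a double bond to nitrogen. Within the data shown here, the steps that bear on this are the two earlier exchanges of the group on the carbon with a double bond to nitrogen, a 1.3-fold higher number from compound 1 to compound 2 (0.12 log units; within the scatter) and a 1.5-fold lower number from compound 2 to compound 3 (0.18 log units; within the scatter), both within the scatter; the methoxy removal a 1.2-fold lower number from compound 1 to compound 3 (0.07 log units; within the scatter) is likewise. No change in this series has moved this assay beyond the scatter, so for compound 4 a step within the scatter is expected, a 1.3-fold higher number from compound 3 to compound 4 (0.10 log units; within the scatter). Compound 4 is estimated at 7000 nM in this assay, with an expected range of 3500 nM to 14000 nM.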

Compound 4, half-maximal inhibitory concentration: 26400 nM
Beside the measured number, compound 4's estimate is 3.8-fold (0.58 log units) below it; measured number outside the range, above it.
By their numbers in this assay, from the lowest: compounds 3, 1 and 2 (each within the scatter of the next); then compound 4.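

In this assay, the group on the carbon with a double bond to nitrogen can change the number beyond the scatter: 4-nitrophenyl gives steps in the same direction from all three earlier compounds (a 4.8-fold higher number from compound 3 to compound 4 (0.68 log units; beyond the scatter); a 3.1-fold higher number from compound 2 to compound 4 (0.49 log units; beyond the scatter); a 4.1-fold higher number from compound 1 to compound 4 (0.61 log units; beyond the scatter)). Compound 4 is therefore the weakest inhibitor of the four, whereas 2-hydroxyphenyl, 2-hydroxy-5-methoxyphenyl and thiophen-2-yl remain within the scatter of one another. No measurement shown explains this step.

Going by these compounds, it remains open whether the step follows the entering nitro group or the departure of the hydroxyl. 4-Hydroxyphenyl and 4-aminophenyl at this position would help separate those two readings.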